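The compounds below may be only part of what the source reports. "The series", "measured", "known", "first", "only" and "open" are said of these compounds alone.

Measured compounds in an ADME assay on microsomes from liver (Homo sapiens) for metabolic stability; on this read-out lower numbers stand for lower hepatic extraction and higher numbers for higher hepatic extraction:

Compound 1, `CC(=O)N1CCC(n2cc(-c3cnc(N)c4oc(-c5cn(C)c6cnccc56)cc34)cn2)CC1`, gives 0.64.
Compound 2, `CC(=O)N1CCC(n2cc(-c3cnc(N)c4oc(-c5cccc6nnsc56)cc34)cn2)CC1`, gives 0.68.
Compound 3, `CC(=O)N1CCC(n2cc(-c3cnc(N)c4oc(-c5csc6cnccc56)cc34)cn2)CC1`, gives 0.68.

Compound 3 stands level with compound 2 at the digits shown, the two together the highest of the three numbers, and its nearest neighbour is compound 2, with no change at the digits printed from compound 2 to compound 3 (within the scatter). Its furthest is compound 1, with a number 0.040 higher from compound 1 to compound 3 (within the scatter). Every step among the three therefore lies within the scatter, and no ordering can be read from them.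

Compound 4, `CC(=O)N1CCC(n2cc(-c3cnc(N)c4oc(-c5cnc6cnccn56)cc34)cn2)CC1`, is the next compound. It differs from compound 3 by a group of 9 heavy atoms (6 carbon, 3 nitrogen; one five-membered aromatic ring with 2 hetero atoms, one six-membered aromatic ring with 2 hetero atoms) in place of a group of 9 heavy atoms (7 carbon, 1 nitrogen, 1 sulfur; one five-membered aromatic ring with 1 hetero atom, one six-membered aromatic ring with 1 hetero atom), on an aromatic carbon, the change sitting on an aromatic carbon of a five-membered aromatic ring with one oxygen, part of a fused or bridged system of two rings, next to the ring oxygen.

Within the data shown here, the steps that bear on this are those in which the group on that same carbon was swapped: a number 0.040 higher from compound 1 to compound 2 (within the scatter), a number 0.040 higher from compound 1 to compound 3 (within the scatter) and no change at the digits printed from compound 2 to compound 3 (within the scatter). All three were small. On that basis compound 4 is expected to show a number 0.030 lower from compound 3 to compound 4 (within the scatter), a step not beyond the scatter in either direction. The estimate for compound 4 is 0.65, with a range from 0.5 to 0.8.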

Compound 4, hepatic extraction ratio: 0
Compound 4: middle estimate off by 0.65, on the high side, outside the stated range (below it).
By their numbers in this assay, from the lowest: compound 4; then compounds 1, 2 and 3 (each within the scatter of the next).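

In this assay this position turns out to be far from indifferent to the group it carries: bringing in the group with 3 nitrogen atoms gives a number 0.68 lower from compound 3 to compound 4 (beyond the scatter) and, against the other two groups, a number 0.68 lower from compound 2 to compound 4 (beyond the scatter) and a number 0.64 lower from compound 1 to compound 4 (beyond the scatter) in turn. The earlier swaps on this aromatic carbon had shown only that three groups could replace one another without a step beyond the scatter, whereas this change shows that the read-out can fall across nearly its whole range, although the entering group has the same count of 9 heavy atoms as the groups in compound 2 and compound 3, and the loss of sulfur alone cannot be the whole story, since compound 1 carries none and stays with the high group. Nothing in the data at hand accounts for the size of this drop.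

The compounds shown leave open which part of the entering group goes with the low number, the five-membered ring with 2 hetero atoms or the six-membered ring with 2 hetero atoms. They also leave open whether that low number would survive a methyl group or an amine added to the entering group.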